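Swapping the nitro group of compound 1 for carbamoyl

This account rests on a few compounds, and the source may have more. Where it says the series, first, only, none or still open, it means among the compounds named here.

Among the compounds with values here, in a functional assay on QG-56 cells (Homo sapiens) for antiproliferative activity (on this read-out lower numbers stand for stronger inhibition and higher numbers for weaker inhibition), compound 1 `COc1cccc(-c2cc([N+](=O)[O-])cc3cc(C(O)(c4ccc(C#N)cc4)c4cncn4C)oc23)c1` gives 38.8 nM, the lowest of the three numbers measured so far. Compound 2 `Cn1cncc1C(O)(c1ccc(C#N)cc1)c1cc2cc([N+](=O)[O-])cc(-c3ccccc3F)c2o1` gives 89.5 nM, and compound 3 `Cn1cncc1C(O)(c1ccc(C#N)cc1)c1cc2cc([N+](=O)[O-])cc(-c3ccc(F)cc3)c2o1` gives 158 nM. Compound 4 `COc1cccc(-c2cc(C(N)=O)cc3cc(C(O)(c4ccc(C#N)cc4)c4cncn4C)oc23)c1` keeps the 3-methoxyphenyl group of compound 1 but has carbamoyl in place of nitro on an aromatic carbon. Within the data shown here, no measured step touches the nitro group. All three exchange the other phenyl substituent instead: a 2.3-fold higher number from compound 1 to compound 2 (0.36 log units; beyond the scatter), a 4.1-fold higher number from compound 1 to compound 3 (0.61 log units; beyond the scatter) and a 1.8-fold higher number from compound 2 to compound 3 (0.25 log units; within the scatter). These steps offer only a rough size for a single change, so the direction is a tentative expectation. The expected result is a modest move upward, a 2.3-fold higher number from compound 1 to compound 4 (0.37 log units; beyond the scatter). For compound 4 the estimated value is 90 nM, with an expected range from 20 nM to 400 nM.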

Compound 4, half-maximal inhibitory concentration: 8.2 nM
For compound 4 the middle estimate is 11-fold (1.04 log units) above the measured one; the measured number lies below the stated range.
By their numbers in this assay, from the lowest: compound 4; then compound 1; then compounds 2 and 3 (each within the scatter of the next).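

In this assay carbamoyl in place of nitro gives a 4.7-fold lower number from compound 1 to compound 4 (0.68 log units; beyond the scatter) and so shows that the nitro group is not needed for a low number on the core of compound 1. The earlier steps shown here changed only the other phenyl substituent, whereas this one shows that the position holding the nitro group also moves the read-out, here downward. Nothing available explains why the number falls.

As far as these compounds go, it remains open whether the same exchange would lower the number with 2-fluorophenyl or 4-fluorophenyl in place of 3-methoxyphenyl. From the compounds shown here alone, how a carboxylic acid or an amine would behave at this position also stays unknown.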